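A few compounds are considered here, and "the series" means these few. Any claim that something is new, unique, unknown or untested is made for them only; others in the source may bear on it.

Measured compounds in a functional assay on HeLa cells (Homo sapiens) for cytotoxicity, read by MTT assay, with a stated time of 48 h; a lower number here means a stronger inhibitor, a higher number a weaker inhibitor:
compound 1 `O=C1C(O)=C(C(c2ccc([N+](=O)[O-])cc2)c2c[nH]c3ccccc23)C(=O)c2ccccc21` gives 14800 nM
compound 2 `O=C1C(O)=C(C(c2cccc([N+](=O)[O-])c2)c2c(-c3ccccc3)[nH]c3ccccc23)C(=O)c2ccccc21` gives 12500 nM
compound 3 `O=C1C(O)=C(C(c2cccc([N+](=O)[O-])c2)c2c[nH]c3ccccc23)C(=O)c2ccccc21` gives 24900 nM

Compound 4 `O=C1C(O)=C(C(c2ccc([N+](=O)[O-])cc2)c2c(-c3ccccc3)[nH]c3ccccc23)C(=O)c2ccccc21` has not yet been measured in this assay. Its core is that of compound 2, whose core differs from the core of compound 3 by phenyl in place of hydrogen on an aromatic carbon; that change gives a 2.0-fold higher number from compound 2 to compound 3 (0.30 log units; within the scatter). The change that leads from compound 2 to compound 4 is 4-nitrophenyl in place of 3-nitrophenyl on a saturated chain carbon bound to an aromatic carbon and a double-bonded ring carbon. The same change has already been made once, from compound 3 to compound 1, as 4-nitrophenyl in place of 3-nitrophenyl on a saturated chain carbon bound to an aromatic carbon and a double-bonded ring carbon, and there it gave a 1.7-fold lower number from compound 3 to compound 1 (0.23 log units; within the scatter). Since the place of the change is the same in both pairs, a step of similar size is expected here. Compound 4 is therefore estimated to give 9000 nM in this assay, with a range from 4500 nM to 18000 nM. That estimate means an expected step of a 1.4-fold lower number from compound 2 to compound 4 (0.14 log units; within the scatter), resting on the step from compound 3 to compound 1.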

Compound 4, half-maximal inhibitory concentration: 6770 nM
For compound 4 the middle estimate is 1.3-fold (0.12 log units) above the measured one; the measured number falls inside the stated range.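

In this assay the change to 4-nitrophenyl in place of 3-nitrophenyl gives a 1.8-fold lower number from compound 2 to compound 4 (0.27 log units; within the scatter) and agrees with the step seen on the other core: the same change on two cores in this assay, a 1.7-fold lower number (0.23 log units; within the scatter) from compound 3 to compound 1 and a 1.8-fold lower number (0.27 log units; within the scatter) from compound 2 to compound 4, 1.1-fold (0.04 log units) apart, within the scatter of two such steps. Phenyl in place of hydrogen on an aromatic carbon gives a 2.2-fold lower number from compound 1 to compound 4 (0.34 log units; beyond the scatter) and likewise agrees with its earlier counterpart: the same change on two cores in this assay, a 2.0-fold higher number (0.30 log units; within the scatter) from compound 2 to compound 3 and a 2.2-fold higher number (0.34 log units; beyond the scatter) from compound 4 to compound 1, 1.1-fold (0.04 log units) apart, within the scatter of two such steps. Among these compounds, each change thus carried over from one core to the other at a similar size, but this rests on only two cores in one assay, and the nitrophenyl step lies within the scatter on both, so it does not show that this change alone makes a real difference.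

The compounds shown leave open whether these steps hold with an amine or a carboxylic acid in place of the nitro group. They also leave open what a methyl group would do in place of the added phenyl.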